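The source may hold more compounds than are shown below. What is called first, only, known or untested is meant among the compounds shown, and "the series" means these compounds.

In an ADME assay on microsomes from liver (Mus musculus) for metabolic stability, read by LC-MS, using NADPH, with stated times of 15 min and 1 h, tested at 4.6 uM (on this read-out higher numbers stand for a longer-lived compound and lower numbers for a shorter-lived compound), compound 1 (`NC1CCc2nc(-c3ccncc3)nc(Nc3ccc(F)cc3)c2C1`) gives > 1 h as a limit and not a number. Compound 2 (`NC1CCc2nc(-c3ccncc3)nc(Nc3cccc(F)c3)c2C1`) gives > 1 h which is likewise a limit, so its standing is known only as a limit. Going by the values given here, the one measured step is a step that the two limits leave unreadable from compound 1 to compound 2 and it offers no size to carry forward, so the expectation rests only on the limit of > 1 h in this assay, at which 2 of the 2 values shown sit, as the evidence at hand. Compound 3 (`CN(C)c1ccc(Nc2nc(-c3ccncc3)nc3c2CC(N)CC3)cc1`) carries 4-(dimethylamino)phenyl in place of 3-fluorophenyl on a nitrogen on an aromatic ring. No direction can be drawn from these data, and the expected step is a number no higher from compound 2 to compound 3 (the limit leaves the size open) with nothing beyond the usual scatter foreseen. For compound 3 the estimated half-life is 1 h with an expected range from 0.4 h to 2 h and this assay may again report only a limit.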

Compound 3, half-life: > 1 h
Compound 3 ended at the assay's limit; the forecaster's own chance of this, stated with the estimate: 55%; the middle value lies on the limit itself.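

No new step can be read between compound 3 and either compound 1 or compound 2, as all three values are limits and not numbers: the limit of > 1 h in this assay, at which 3 of the 3 values shown sit.

The compounds shown leave open how long each one actually lasts in this assay and whether swapping these groups on the nitrogen changes half-life at all.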